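The compounds below may be only part of what the source reports. "The series", "measured", "known", "first", "only" and "open" are said of these compounds alone.

Compound 1 `Cc1cc(CNS(=O)(=O)c2ccc([N+](=O)[O-])cc2)c(C)s1` gives only a limit in an ADME assay on MDCK cells (Canis lupus familiaris) for cytotoxicity, read by MTT assay, with a stated time of 24 h (a higher number here means that more compound is tolerated, a lower number that less compound is tolerated), namely > 204000 nM. Compound 2 `Cc1cc(CNS(=O)(=O)c2ccc(C#N)cc2)c(C)s1` also gives only a limit, > 217000 nM. Between these two stands a step that the two limits leave unreadable from compound 1 to compound 2, so compound 1 cannot be ranked against compound 2. Compound 3 `Cc1cc(CNS(=O)(=O)c2ccc(Cl)cc2)c(C)s1` gives a true number in this assay, 52900 nM. Chloro in place of nitro goes with an at least 3.8-fold lower number from compound 1 to compound 3 (0.58 log units; beyond the scatter), and chloro in place of cyano goes with an at least 4.1-fold lower number from compound 2 to compound 3 (0.61 log units; beyond the scatter).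

Compound 4 `O=[N+]([O-])c1ccc(S(=O)(=O)NCc2ccc(Cl)s2)cc1` keeps the nitro group of compound 1 and changes the other side of the sulfonamide: 5-chlorothiophen-2-yl in place of 2,5-dimethylthiophen-3-yl on a saturated chain carbon bound to a sulfonamide nitrogen. Within the data shown here, no measured step changes this group, so the evidence is indirect. Among the measured compounds shown here, the only loose guide is that the one chloro-bearing compound, compound 3 at 52900 nM, is also the only one that gives a number, through an at least 3.8-fold lower number from compound 1 to compound 3 (0.58 log units; beyond the scatter). A lower number is therefore expected in this assay, though a step of similar size is only a tentative reading. The expected change is an at least 1.8-fold lower number from compound 1 to compound 4 (0.26 log units; that floor lies within the scatter). The estimated value for compound 4 is 110000 nM, with an expected range of 35000 nM to 300000 nM.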

Compound 4, half-maximal cytotoxic concentration: 128000 nM
For compound 4 the middle estimate is 1.2-fold (0.07 log units) below the measured one, within the range that was stated.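

Among these compounds, replacing 2,5-dimethylthiophen-3-yl with 5-chlorothiophen-2-yl on a saturated chain carbon bound to a sulfonamide nitrogen gives the first reading of a change on this side of the sulfonamide in this assay, with an at least 1.5-fold lower number from compound 1 to compound 4 (0.20 log units; that floor lies within the scatter) as the step. Compound 4 also shows that keeping the nitro group does not confine a compound in this series to a limit, since it gives a true number while carrying that group. Going by these compounds, compound 1 still gives only a limit and not a number, so the step is a floor and its true size remains unknown: the limit of > 204000 nM in this assay, at which 1 of the 4 values shown sits.

The whole group changes in this one step, so the contribution of the chlorine cannot be separated from the loss of the two methyl groups or from the different ring attachment named by the two group names. An unsubstituted thiophen-2-yl on the same chain carbon would address that question, while an amine in place of nitro on the aromatic carbon, paired with 5-chlorothiophen-2-yl, would test whether the aromatic and thiophene changes act independently.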